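A few compounds are considered here, and "the series" means these few. Any claim that something is new, unique, unknown or untested is made for them only; others in the source may bear on it.

In a functional assay on MES-SA cells (Homo sapiens) for inhibition, with a stated time of 72 h (on this read-out higher numbers stand for weaker inhibition and lower numbers for stronger inhibition), compound 1 (`Oc1c(CN2CCCCC2)ccc2cccnc12`) gives 5210 nM; 5130 nM (2 entries), compound 2 (`Oc1c(CN2CCCC2)cc(Cl)c2cccnc12`) gives 3460 nM; 3390 nM (2 entries), and compound 3 (`Oc1c(CN2CCCC2)cc(Br)c2cccnc12`) gives 3800 nM. Going by the values given here, for compound 3 this is the only number available, as two further entries for it carry no single figure. All three values lie within the usual scatter of one another, so compound 3 stands level with the other two.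

Compound 4 (`CCOCc1cc(CN2CCCC2)c(O)c2ncccc12`) has not yet been measured. It has ethoxymethyl in place of bromo on an aromatic carbon, para to a hydroxy group: ethoxymethyl in place of bromo on an aromatic carbon. Among the compounds with values here, no measured pair isolates a change at this place, so the expectation is only a loose one. The values stay close across the series, with compound 1 at 5210 nM; 5130 nM (2 entries) and compound 3 at 3800 nM, so a small drift towards weaker inhibition is expected, with nothing beyond the scatter. The estimate means a 1.3-fold higher number from compound 3 to compound 4 (0.12 log units; within the scatter), an expected step of modest size. In this assay, the estimated value for compound 4 is 5000 nM, with an expected range from 2500 nM to 10000 nM.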

Compound 4, half-maximal inhibitory concentration: 8510 nM
For compound 4 the middle estimate is 1.7-fold (0.23 log units) below the measured one; the range from low to high includes it.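

Going by these compounds alone, this is the first step that isolates the aromatic carbon para to a hydroxy group, and it shows that this position is not indifferent to what sits there: in this assay, ethoxymethyl in place of bromo gives a 2.2-fold higher number from compound 3 to compound 4 (0.35 log units; beyond the scatter), which means weaker inhibition. The change is modest, yet repeat entries in this assay agree closely, as with compound 2: the several entries of compound 2 in this assay, 3460 nM; 3390 nM (2 entries). The swap brings in more heavy atoms and a hydrogen-bond acceptor together, so this one step cannot tell which of the two matters.

The compounds shown leave open whether the chain's length or its oxygen accounts for the shift. A butyl chain, an amine such as aminomethyl, or a carboxylic acid at this position would help to separate these possibilities.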